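Methyl on the hydroxy group of compound 1

The compounds below may be only part of what the source reports. "The series", "measured", "known", "first", "only" and "open" are said of these compounds alone.

- Compound 1 `O=C(NCCCNc1cc(-c2cn(-c3ccccc3)nc2-c2cccc(O)c2)ccn1)Nc1ccc(F)cc1` gives 1380 nM in the measurements so far
- Compound 2 `O=C(NCCCNc1cc(-c2cn(-c3ccccc3)nc2-c2cccc(O)c2)ccn1)Nc1cccc(C(F)(F)F)c1` gives 1760 nM in the measurements so far

Going by the values given here, in a functional assay on SF-295 cells (Homo sapiens) for antiproliferative activity, read by sulforhodamine B assay, with a stated time of 48 h (on this read-out higher numbers stand for weaker inhibition and lower numbers for stronger inhibition), compound 1 and compound 2 stand within the scatter of each other, the only measured step being a 1.3-fold higher number from compound 1 to compound 2 (0.11 log units; within the scatter) at another place in the molecule. Compound 3 `COc1cccc(-c2nn(-c3ccccc3)cc2-c2ccnc(NCCCNC(=O)Nc3ccc(F)cc3)c2)c1` differs from compound 1 by methyl in place of hydrogen on an oxygen on an aromatic ring and reads as hydroxy to methoxy. Among the compounds with values here, no measured step touches this site, so no step beyond the scatter is expected in this assay on present evidence. The estimated 1.4-fold higher number from compound 1 to compound 3 (0.16 log units; within the scatter) is only a slight expected move. For compound 3 the expected value is 2000 nM with an estimated range from 800 nM to 5500 nM in this wide estimate.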

Compound 3, half-maximal inhibitory concentration: 7160 nM
Compound 3: middle estimate off by 3.6-fold (0.55 log units), on the low side; the whole stated range lies below it.
By their numbers in this assay, from the lowest: compounds 1 and 2 (each within the scatter of the next); then compound 3.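

In this assay, replacing hydrogen with methyl on this oxygen, hydroxy to methoxy, gives a 5.2-fold higher number from compound 1 to compound 3 (0.72 log units; beyond the scatter). Going by these compounds alone, this is the first step beyond the scatter, so the 3-hydroxyphenyl position responds to this change, while the step at the other place, a 1.3-fold higher number from compound 1 to compound 2 (0.11 log units; within the scatter), stays within it. Nothing in the data given bears on the reason for this weaker inhibition.

As far as these compounds go, how an amino group or an ethoxy group would read at this position remains open. So does whether methoxy would shift compound 2 by a similar amount.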